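The source may hold more compounds than are shown below. What is called first, only, known or untested is meant among the compounds shown, and "the series" means these compounds.

Of the compounds shown here, two have numbers so far. In a functional assay on SF-539 cells (Homo sapiens) for inhibition (on this read-out lower numbers stand for stronger inhibition of growth and higher numbers for weaker inhibition of growth), compound 1 (`NS(=O)(=O)c1ccc(/C=C/c2ccc(F)cc2)cc1`) gives 29100 nM and compound 2 (`NS(=O)(=O)c1ccc(/C=C/c2cccc(O)c2)cc1`) gives 36700 nM on the same read-out. These two values lie within the scatter of each other, so compound 1 stands level with compound 2 and the pair cannot be ranked.

The next step leads to compound 3 (`CN(C)c1ccc(/C=C/c2ccc(S(N)(=O)=O)cc2)cc1`), which keeps the core of compound 1. The change is dimethylamino in place of fluoro on an aromatic carbon, para to a large group (dimethylamino in place of fluoro on an aromatic carbon). Among the measured compounds shown here, no measured pair isolates a single change, so this step has no direct precedent. For the measured compounds named here, the only guide is the narrow spread between compound 1 at 29100 nM and compound 2 at 36700 nM in the data so far.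

On that thin basis, no step beyond the scatter is expected, with a slight lean towards a lower number. The estimated change is a 1.5-fold lower number from compound 1 to compound 3 (0.16 log units; within the scatter) and it is expected to stay within the scatter. Compound 3 is expected at 20000 nM with an estimated range from 7000 nM to 50000 nM in this assay when measured.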

Compound 3, concentration for 50% growth inhibition: 11700 nM
Compound 3: the middle estimate sits 1.7-fold (0.23 log units) above what was measured; the range from low to high includes it.
By their numbers in this assay, from the lowest: compound 3; then compounds 1 and 2 (each within the scatter of the next).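

Dimethylamino in place of fluoro on an aromatic carbon, para to a large group, gives the first change in the series that can be read on its own: in this assay it produces a 2.5-fold lower number from compound 1 to compound 3 (0.40 log units; beyond the scatter). This shows that the position responds to the choice of group, though the step is modest, and that growth inhibition is not lost when 1 heavy atom gives way to 3 heavy atoms, including a hydrogen-bond acceptor. Nothing at hand accounts for the step, and no measured property of these compounds bears on it.

A single pair cannot separate the contributions of group size, the nitrogen and the two methyl groups, so no trend can yet be drawn at this position. An amine without methyl groups, a methoxy group or the longer diethylamino group at the same place would help to separate them, while the same change on a core bearing the hydroxyl of compound 2 would test whether the step carries over.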